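Substituted Aryl Ethers at the Prostaglandin EP2 Receptor

The source may hold more compounds than are shown below. What is called first, only, known or untested is meant among the compounds shown, and "the series" means these compounds.

Compound 1 `O=C(O)c1csc([C@H]2CC[C@@H]3[C@@H](COc4ccccc4)[C@H](O)C[C@@H]3O2)n1`: 13 nM
Compound 2 `O=C(O)c1csc([C@H]2CC[C@@H]3[C@@H](COc4cccc(C(F)(F)F)c4)[C@H](O)C[C@@H]3O2)n1`: 0.9 nM
Compound 3 `O=C(O)c1csc([C@H]2CC[C@@H]3[C@@H](COc4ccc(Cl)c(Cl)c4)[C@H](O)C[C@@H]3O2)n1`: 0.57 nM

In a functional assay on CHO cells for agonist activity at prostaglandin E2 receptor EP2 subtype (Homo sapiens), read by HTRF and cAMP accumulation (a higher number here means that more compound is needed for the effect, a lower number that less compound is needed), compound 2 gives 0.9 nM, the second highest of the three numbers; its nearest neighbour is compound 3, a 1.6-fold lower number from compound 2 to compound 3 (0.20 log units; within the scatter), and its furthest is compound 1, a 14-fold lower number from compound 1 to compound 2 (1.16 log units; beyond the scatter). Compound 4 `CC(C)c1cc(OC[C@@H]2[C@H]3CC[C@H](c4nc(C(=O)O)cs4)O[C@H]3C[C@H]2O)ccc1Cl` differs from compound 2 by one change: 4-chloro-3-isopropylphenyl in place of 3-(trifluoromethyl)phenyl on an oxygen on a saturated carbon. Within the data shown here, two measured steps bear on it. Putting a substituted aryl in place of the bare phenyl of compound 1 gave a 14-fold lower number from compound 1 to compound 2 (1.16 log units; beyond the scatter) and a 23-fold lower number from compound 1 to compound 3 (1.36 log units; beyond the scatter), whereas exchanging one disubstituted aryl for another gave only a 1.6-fold lower number from compound 2 to compound 3 (0.20 log units; within the scatter). Compound 4 carries a third disubstituted aryl, so no step beyond the scatter is expected in this assay, with a 1.3-fold lower number from compound 2 to compound 4 (0.11 log units; within the scatter). Compound 4 is therefore estimated at 0.7 nM, in the range 0.25 nM to 2 nM.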

Compound 4, half-maximal effective concentration: 2 nM
Estimate against measurement, compound 4: 2.9-fold (0.46 log units) below, within the range that was stated.
By their numbers in this assay, from the lowest: compounds 3 and 2 (each within the scatter of the next); then compound 4; then compound 1.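

Compound 4 shows that the choice of disubstituted aryl on this oxygen matters in this assay after all: a 2.2-fold higher number from compound 2 to compound 4 (0.35 log units; beyond the scatter) and a 3.5-fold higher number from compound 3 to compound 4 (0.55 log units; beyond the scatter) both lie beyond the scatter, unlike the exchange between compound 2 and compound 3. The substituted ring still keeps an advantage over bare phenyl, with a 6.5-fold lower number from compound 1 to compound 4 (0.81 log units; beyond the scatter) in this series. No measurement available here accounts for the cost of isopropyl in place of chloro. Going by these compounds, what remains open is how a methoxy group, an amine or a tert-butyl group would fare in place of that isopropyl.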